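A Phenyl Swap on Compound 3

The source may hold more compounds than are shown below. What is called first, only, known or untested is meant among the compounds shown, and "the series" means these compounds.

Measured so far in a functional assay on MCF7 cells (Homo sapiens) for cytotoxicity, read by MTT assay, with a stated time of 72 h; on this read-out higher numbers stand for weaker inhibition and lower numbers for stronger inhibition:
- Compound 1 `COc1cc2ncnc(Nc3ccc(F)c(Cl)c3)c2cc1NC(=O)/C=C/c1ccc(F)cc1Cl`: "not active" (no number reported)
- Compound 2 `O=C(/C=C/c1ccccc1[N+](=O)[O-])Nc1cc2c(Nc3ccc(F)c(Cl)c3)ncnc2cc1O[C@H]1CCOC1`: 28400 nM
- Compound 3 `COc1cc(/C=C/C(=O)Nc2cc3c(Nc4ccc(F)c(Cl)c4)ncnc3cc2O[C@H]2CCOC2)cc(OC)c1`: 30300 nM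

Only compound 2 and compound 3 have numbers, and these two sit level within the usual scatter. Compound 1 was reported without a number.

The next molecule, compound 4 `O=C(/C=C/c1ccc(F)cc1Cl)Nc1cc2c(Nc3ccc(F)c(Cl)c3)ncnc2cc1O[C@H]1CCOC1`, keeps the rest of compound 3 but changes one group: 2-chloro-4-fluorophenyl in place of 3,5-dimethoxyphenyl, on a double-bonded chain carbon bound to a double-bonded chain carbon (2-chloro-4-fluorophenyl in place of 3,5-dimethoxyphenyl on a double-bonded chain carbon bound to a double-bonded chain carbon).

One measured step changes the same place: a 1.1-fold higher number from compound 2 to compound 3 (0.03 log units; within the scatter). Within the data shown here, it stays within the scatter, so a swap here has not yet been seen to move the number in this assay. Compound 4 shares its new group with compound 1, which differs elsewhere in the molecule and gave "not active" (no number reported), so a result without a number also remains possible.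

No change beyond the scatter is therefore expected, and the estimated step is a 1.0-fold lower number from compound 3 to compound 4 (0.00 log units; within the scatter). For compound 4, the estimate is 30000 nM, with an expected range from 12000 nM to 75000 nM.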

Compound 4, half-maximal inhibitory concentration: 26200 nM
Beside the measured number, compound 4's estimate is 1.1-fold (0.06 log units) above it, and the stated range covers the measured number.
By their numbers in this assay, from the lowest: compounds 4, 2 and 3 (each within the scatter of the next).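

In this assay, a third phenyl group on the double-bonded chain carbon, 2-chloro-4-fluorophenyl, gives a 1.2-fold lower number from compound 3 to compound 4 (0.06 log units; within the scatter) and a 1.1-fold lower number from compound 2 to compound 4 (0.04 log units; within the scatter) at this same place. Going from 3,5-dimethoxyphenyl to this group changes the counts of heavy atoms and hydrogen-bond acceptors, yet compound 3 and compound 4 still sit level, as do compound 2 and compound 4. Compound 4 also carries a number, whereas compound 1, which has the same group and differs elsewhere in the molecule, is reported as "not active" (no number reported) in this assay, so this group does not by itself go with a result lacking a number.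

Going by these compounds, whether something other than a substituted phenyl at this place, such as an amine, a carboxylic acid or a longer chain, would move the number stays open. Nothing shown gives a reason for these level numbers.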